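Cyclopropyl for 1,3-oxazol-4-yl on compound 3

The source may hold more compounds than are shown below. What is called first, only, known or untested is meant among the compounds shown, and "the series" means these compounds.

In an ADME assay on the whole organism (strain Wistar Han) for metabolic stability, with Rattus norvegicus as the target, read by LC-MS, at a dose of 5 mg/kg by the oral route (on this read-out higher numbers stand for a longer-lived compound and lower numbers for a shorter-lived compound), compound 1 `N#Cc1ccc(C(O)(c2cocn2)C(F)(F)F)cc1C(F)(F)F` gives 8 h and compound 2 `N#Cc1ccc(C(O)(C2CC2)C(F)(F)F)cc1C(F)(F)F` gives 20 h while compound 3 `Cc1c(C(O)(c2cocn2)C(F)(F)F)ccc(C#N)c1C(F)(F)F` gives 5.5 h on the same read-out. Compound 3 therefore stands within the scatter of compound 1, and its number is well under that of compound 2.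

The next structure is compound 4 `Cc1c(C(O)(C2CC2)C(F)(F)F)ccc(C#N)c1C(F)(F)F` with cyclopropyl in place of 1,3-oxazol-4-yl on a saturated chain carbon bound to an aromatic carbon, an oxygen on a saturated carbon and a saturated chain carbon as the only difference, cyclopropyl in place of 1,3-oxazol-4-yl. The same exchange appears once among the measured pairs, with a 2.5-fold higher number from compound 1 to compound 2 (0.40 log units; beyond the scatter) as a modest result. Methyl in place of hydrogen on an aromatic carbon gave a 1.5-fold lower number from compound 1 to compound 3 (0.16 log units; within the scatter) and so offers no ground to expect a different size on the core of compound 3. A step of like size and upward direction is expected, though this rests on one pair only, and the expected move is a 2.5-fold higher number from compound 3 to compound 4 (0.41 log units; beyond the scatter) in this assay on this basis. Compound 4 is estimated at 14 h with an expected range from 7.5 h to 26 h for most repeat measurements.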

Compound 4, half-life: 10 h
Compound 4: the middle estimate sits 1.4-fold (0.15 log units) above what was measured; the range from low to high includes it.
By their numbers in this assay, from the lowest: compounds 3, 1, 4 and 2 (each within the scatter of the next, the first and the last beyond it).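

In this assay, a 1.8-fold higher number from compound 3 to compound 4 (0.26 log units; within the scatter) lies within the scatter, whereas the same exchange on the core of compound 1 lay beyond it, yet the two steps cannot be told apart: the same change on two cores in this assay, a 2.5-fold higher number (0.40 log units; beyond the scatter) from compound 1 to compound 2 and a 1.8-fold higher number (0.26 log units; within the scatter) from compound 3 to compound 4, 1.4-fold (0.14 log units) apart, within the scatter of two such steps. Methyl in place of hydrogen on an aromatic carbon can now also be read on a second core, where a 2.0-fold lower number from compound 2 to compound 4 (0.30 log units; within the scatter) again lies within the scatter, and these two steps also agree: the same change on two cores in this assay, a 1.5-fold lower number (0.16 log units; within the scatter) from compound 1 to compound 3 and a 2.0-fold lower number (0.30 log units; within the scatter) from compound 2 to compound 4, 1.4-fold (0.14 log units) apart, within the scatter of two such steps. Across these four compounds, neither change is seen to depend on the other.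

As far as these compounds go, what an amine or a longer chain would give in place of cyclopropyl, on a saturated chain carbon bound to an aromatic carbon, an oxygen on a saturated carbon and a saturated chain carbon, remains open. From the compounds shown here alone, whether either step keeps its size on any further core also remains open.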